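The source may report more compounds than this note shows. Statements on the series, on what has been measured and on what is new or still open speak of the compounds shown alone.

Working notes on the series. The shared core is that of compound 1 `CNc1nc(SC)nc2c1ncn2[C@@H]1C[C@@H](O)[C@H](CO)O1`. In a functional assay on B-95-8 cells (Cercopithecidae) with B-95-8 cell line (Saguinus oedipus) as the target (on this read-out higher numbers stand for weaker inhibition and lower numbers for stronger inhibition), compound 1 gives > 300 uM, which is a limit of the assay and not a number. For the measured compounds named here, compound 2 `CSc1nc(N(C)C)c2ncn([C@@H]3C[C@@H](O)[C@H](CO)O3)c2n1` holds the only number in this assay: compound 2 gives 116 uM. Going by the values given here, the one measured step, an at least 2.5-fold lower number from compound 1 to compound 2 (0.41 log units; beyond the scatter), goes toward stronger inhibition on methylation of the nitrogen; its size is known only as a bound, see (the limit of > 300 uM in this assay, at which 1 of the 2 values shown sits).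

Compound 3 `CSc1nc(N)c2ncn([C@@H]3C[C@@H](O)[C@H](CO)O3)c2n1` carries amino in place of dimethylamino on an aromatic carbon. This removes the methyls from that nitrogen, running opposite to the direction seen in the measured step, so a step toward a higher number is expected in this assay, its size open because an at least 2.5-fold lower number from compound 1 to compound 2 (0.41 log units; beyond the scatter) is itself only a lower bound. Compound 3 is expected near 300 uM, within 120 uM to 1000 uM, an estimated step of a 2.6-fold higher number from compound 2 to compound 3 (0.41 log units; beyond the scatter), with a fair chance that only a limit is reported.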

Compound 3, concentration for 50% inhibition: > 300 uM
Compound 3: only a limit was reported (the forecaster's own chance of this, stated with the estimate: 60%); the middle value sits exactly at the limit.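

Amino in place of dimethylamino on this aromatic carbon gives an at least 2.5-fold higher number from compound 2 to compound 3 (0.41 log units; beyond the scatter) in this assay, so both compounds with fewer methyls on this nitrogen now end at a limit, and only the dimethylamino compound carries a number. Compound 3 gives > 300 uM, which is a limit of the assay and not a number. The step between the methylamino and amino compounds cannot be read, because both sit at that limit: the limit of > 300 uM in this assay, at which 2 of the 3 values shown sit.

From the compounds shown here alone, how far these two compounds lie beyond the limit stays open, and with it the true size of each step away from dimethylamino. Also open, going by these compounds, is whether diethylamino or a cyclic amine such as morpholine on this carbon would give a lower number than compound 2 with its 116 uM.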